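Saturating the fused ring of an aryl indazole

The source may report more compounds than this note shows. Statements on the series, on what has been measured and on what is new or still open speak of the compounds shown alone.

Measured compounds:
compound 1 `O=C(O)CCNC(=O)c1ccc(C(Oc2ccc(-n3cc(C(F)(F)F)cn3)cc2)C2CC2)cc1` gives 1300 nM
compound 2 `CCCC(Oc1ccc(-n2cc3ccccc3n2)cc1)c1ccc(C(=O)NCCC(=O)O)cc1` gives 290 nM
compound 3 `CCCC(Nc1cc(C)c(-n2cc(C(F)(F)F)cn2)c(C)c1)c1ccc(C(=O)NCCC(=O)O)cc1` gives 12 nM

All three numbers come from an assay on cells for displacement of a labelled ligand from Glucagon receptor (Homo sapiens), in the presence of a further agent that is not named here; a lower number here means a stronger inhibitor, a higher number a weaker inhibitor. Among them, compound 2 holds the second highest value. Its nearest neighbour is compound 1, whose number is higher and sits beyond the usual scatter; the furthest is compound 3, whose number is much lower, again beyond the scatter. So compound 2 lies between a clearly weaker and a clearly stronger analogue.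

Compound 4 `CCCC(Oc1ccc(-n2cc3c(n2)CCCC3)cc1)c1ccc(C(=O)NCCC(=O)O)cc1` has not been measured. Compared with compound 2, the change is a group of 9 heavy atoms (7 carbon, 2 nitrogen; one five-membered aromatic ring with 2 hetero atoms, one six-membered non-aromatic ring of carbon only) in place of a group of 9 heavy atoms (7 carbon, 2 nitrogen; one five-membered aromatic ring with 2 hetero atoms, one six-membered aromatic ring of carbon only), on an aromatic carbon. The two groups are the same size, and the only difference is that the six-membered carbon ring fused to the five-membered ring is aromatic in compound 2 and non-aromatic in compound 4.

Among the measured compounds shown here, no pair among the measured compounds isolates this kind of change, so its effect on this assay is not known from the data. The heteroaryl group in compound 1 and compound 3 differs in other ways as well and offers no direct guide. A step of modest size is expected, most likely toward a somewhat higher number, and it may fall within the scatter.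

For compound 4 an inhibition constant of 400 nM is expected, with a range from 120 nM to 1400 nM, an estimated step of a 1.4-fold higher number from compound 2 to compound 4 (0.14 log units; within the scatter).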

Compound 4, inhibition constant: 690 nM
Compound 4: middle estimate off by 1.7-fold (0.24 log units), on the low side; measured number inside the range.
By their numbers in this assay, from the lowest: compound 3; then compound 2; then compounds 4 and 1 (each within the scatter of the next).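

In this assay, among the compounds shown here, saturating the fused six-membered carbon ring gives a 2.4-fold higher number from compound 2 to compound 4 (0.38 log units; beyond the scatter), the first change in this set that can be followed at a single place. On this aromatic carbon, para to a large group, the two groups have the same number of heavy atoms and the same counts of hydrogen-bond donors and acceptors, so those counts alone do not decide the result. The only difference is whether the fused ring is aromatic, and here the aromatic ring of the 2H-indazol-2-yl group goes with the lower number, though nothing measured here explains why that is so.

This single pair leaves open whether the same step would appear on the core of compound 3, which differs from compound 2 in more than one place, so the pair says nothing direct about that core. It also leaves open how the number would respond to other fused rings at this position, such as a pyridine ring, a fused five-membered carbon ring, or a saturated ring carrying a hydroxyl group.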